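Stretching the alkyne chain on a bis-benzimidazole core

A few compounds are considered here, and "the series" means these few. Any claim that something is new, unique, unknown or untested is made for them only; others in the source may bear on it.

Compound 1, `C#CCCCCOc1ccc(-c2nc3ccc(-c4nc5ccc(N6CCN(C)CC6)cc5[nH]4)cc3[nH]2)cc1`, and compound 2, `C#CCOc1ccc(-c2nc3ccc(-c4nc5ccc(N6CCN(C)CC6)cc5[nH]4)cc3[nH]2)cc1`, share one core and differ only in the chain that carries the triple bond on the oxygen-bound side. Both were tested in an assay on isolated protein for inhibition of DNA topoisomerase 1 (Homo sapiens), with a stated time of 30 min; on this read-out higher numbers stand for weaker inhibition and lower numbers for stronger inhibition. For compound 1 this assay gives only a limit, > 50000 nM, and no number. Compound 2 gives 25400 nM, which is the only actual number shown. The other value shown is that of compound 1: the limit of > 50000 nM in this assay, at which 1 of the 2 values shown sits. For the measured compounds named here, the single measured step, an at least 1.9-fold lower number from compound 1 to compound 2 (0.29 log units; that floor lies within the scatter), shortens the chain, and its floor sits within the scatter.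

Compound 3, `C#CCCCCCCCCCOc1ccc(-c2nc3ccc(-c4nc5ccc(N6CCN(C)CC6)cc5[nH]4)cc3[nH]2)cc1`, goes the other way and much further: dec-9-yn-1-yl in place of ethynyl on a saturated chain carbon bound to an oxygen on an aromatic ring. Going by the values given here, only the step from compound 1 to compound 2 bears on this move, and it runs in the opposite direction, so it gives the direction but not a firm size. Since the longer-chained compound 1 sat at the limit, compound 3 is expected to show a higher number again, around a 2.4-fold higher number from compound 2 to compound 3 (0.37 log units; beyond the scatter), and quite possibly only a limit. The estimate for compound 3 in this assay is 60000 nM, with a range from 20000 nM to 200000 nM.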

Compound 3, half-maximal inhibitory concentration: > 50000 nM
Compound 3 gave a limit, no number; the forecaster's own chance of this, stated with the estimate: 65%; the middle value does not contradict the limit.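

In this assay compound 3 gives > 50000 nM, which is a limit and not a number. Going from ethynyl to dec-9-yn-1-yl on this saturated chain carbon bound to an oxygen on an aromatic ring gives an at least 1.9-fold higher number from compound 2 to compound 3 (0.29 log units; that floor lies within the scatter), so this much longer chain, like the chain of compound 1, yields no actual number, and the firm part of the step still does not clear the usual scatter. Compound 1 and compound 3 both end at limits, so the step between them cannot be read and their two chains cannot be ranked against each other, and the limit now holds most of the series: the limit of > 50000 nM in this assay, at which 2 of the 3 values shown sit.

Going by these compounds, the true values of compound 1 and compound 3 stay open, and with them how much, if at all, chain length matters at this position beyond what the floor shows. All the compounds shown keep a triple bond in the chain, so it also stays open whether a chain carrying an amine or a carboxylic acid in its place would give a number in this assay.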